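Trimming a large side group back to ethyl

The source may hold more compounds than are shown below. What is called first, only, known or untested is meant among the compounds shown, and "the series" means these compounds.

Of the three compounds measured in a physicochemical assay for lipophilicity, in phosphate buffer, measured as octanol-water partition, at pH 6.8 (a higher number here means a more lipophilic compound, a lower number a more polar compound), compound 3 `Cc1c(-c2ccccc2)c(N2CC[C@H](N(C)C)C2)n2nc(C(C)(C)COCc3ccccc3)nc2c1C#N` stands highest at 3.8. Compound 2 `CCCCc1nc2c(C#N)c(C)c(-c3ccccc3)c(N3CC[C@H](N(C)C)C3)n2n1` gives 3.2, and compound 1 `Cc1cn2c(N3CC[C@H](N(C)C)C3)c(-c3ccccc3)c(C)c(C#N)c2n1` gives 1.9. Going by the values given here, the only step between compounds that differ in a single place runs a number 0.60 log units higher from compound 2 to compound 3 (beyond the scatter), a modest rise. Compound 4 `CCc1nc2c(C#N)c(C)c(-c3ccccc3)c(N3CC[C@H](N(C)C)C3)n2n1` differs from compound 3 by ethyl in place of 1-((benzyloxy)methyl)-1-methylethyl on an aromatic carbon. That earlier step bears directly on this change and is reversed here, then carried further: ethyl is shorter than butyl, so the number should fall past compound 2, which gave 3.2 with butyl in that place. The expected step is a number 1.40 log units lower from compound 3 to compound 4 (beyond the scatter). Compound 4 is therefore estimated at 2.4, within 1.9 to 2.9.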

Compound 4, distribution coefficient: 2.1
Estimate against measurement, compound 4: 0.30 log units above; low and high end bracket the measured number.
By their numbers in this assay, from the lowest: compounds 1 and 4 (each within the scatter of the next); then compound 2; then compound 3.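

In this assay this position on the aromatic carbon is now sensitive to chain length alone: going from butyl to ethyl gives a number 1.10 log units lower from compound 2 to compound 4 (beyond the scatter), a large step and larger than the modest a number 0.60 log units higher from compound 2 to compound 3 (beyond the scatter). Replacing 1-((benzyloxy)methyl)-1-methylethyl with ethyl gives a number 1.70 log units lower from compound 3 to compound 4 (beyond the scatter), so most of that fall comes with the shorter chain rather than with the loss of the six-membered aromatic ring. Nothing available explains these steps. The compounds shown leave open how a propyl chain would fall within this range, and how an amine or a carboxylic acid at this place would read.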